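A few compounds are considered here, and "the series" means these few. Any claim that something is new, unique, unknown or untested is made for them only; others in the source may bear on it.

Compound 1 `CCCN(CCC)c1cc2[nH]c(C3CCCCC3)nc2cc1NC(=O)c1ccccc1`: in an ADME assay on Vero cells (Chlorocebus sabaeus) for cytotoxicity, read by resazurin assay, with a stated time of 3 days (a lower number here means a stronger inhibitor, a higher number a weaker inhibitor), compound 1 gives > 100 ug/mL, which is a limit of the assay.
Compound 2 `CCCc1ccc(C(=O)Nc2cc3nc(C4CCCCC4)[nH]c3cc2N(C)C)cc1`: in this assay compound 2 gives > 100 ug/mL, also a limit.
Compound 3 `CCCCCC(=O)Nc1cc2nc(C3CCCCC3)[nH]c2cc1N(C)C`: in this assay compound 3 gives > 100 ug/mL, again a limit.

Compound 3 therefore stands at the limit, as do the two others, and no order among the three can be read. Within the data shown here, the single measured step, a step that the two limits leave unreadable from compound 2 to compound 3, has no readable size because the limit of > 100 ug/mL in this assay, at which 3 of the 3 values shown sit, caps both of its ends.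

Compound 4 `CN(C)c1cc2[nH]c(C3CCCCC3)nc2cc1NC(=O)c1ccccc1` differs from compound 3 by phenyl in place of pentyl on a carbonyl carbon. Among the measured compounds shown here, the only measured step that bears on this place, the step from compound 2 to compound 3, exchanged a pentyl for an aryl group on the same carbonyl carbon and stayed at the limit on both sides, so it gives no size to carry over. For compound 4 no step beyond the scatter is expected, a step that the limit leaves unreadable from compound 3 to compound 4. Compound 4 is estimated at 150 ug/mL in this assay, with a range from 60 ug/mL to 400 ug/mL, most likely reported only as a limit.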

Compound 4, half-maximal inhibitory concentration: > 100 ug/mL
Compound 4: only a limit was reported; the forecaster's own chance of this, stated with the estimate: 85%; the middle value is on the limit's open side.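

The steps from compound 1, compound 2 and compound 3 to compound 4 cannot be read in this assay because all four compounds sit at one limit: the limit of > 100 ug/mL in this assay, at which 4 of the 4 values shown sit.

Left open is where each compound's true value lies, and whether any of these exchanges changes the read-out at all.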